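Lengthening a small amide chain on compound 2

This account rests on a few compounds, and the source may have more. Where it says the series, first, only, none or still open, it means among the compounds named here.

compound 1 `CCC1C(=O)N(C)c2cnc(Nc3ccc(S(=O)(=O)NCC(C)C)cc3)nc2N1c1ccn(C)n1` gives 8350 nM
compound 2 `CCC1C(=O)N(C)c2cnc(-n3ccc4cc(C(=O)NC)ccc43)nc2N1c1ccn(C)n1` gives 35400 nM
compound 3 `CCCNC(=O)c1ccc2c(ccn2-c2ncc3c(n2)N(C2CCCC2)[C@H](CC)C(=O)N3C)c1` gives 592 nM

These three numbers come from a functional assay on MCF7 cells (Homo sapiens) for antiproliferative activity, read by CCK-8 assay, with a stated time of 72 h; on this read-out lower numbers stand for stronger inhibition of growth and higher numbers for weaker inhibition of growth. Compound 2 has the highest number of the three, and its gaps to compound 1 and compound 3 both lie beyond the scatter, so it inhibits growth the least.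

Compound 4 `CCC1C(=O)N(C)c2cnc(-n3ccc4cc(C(=O)NCC(C)C)ccc43)nc2N1c1ccn(C)n1` keeps compound 2 intact except for one change: isopropyl in place of hydrogen on a saturated chain carbon bound to an amide-type nitrogen. This turns methylcarbamoyl into isobutylcarbamoyl.

For the measured compounds named here, no measured pair isolates this change, so the evidence is indirect. Compound 1 also carries an isobutyl group, on a different scaffold, and gives 8350 nM. Compound 3 has a propyl chain on its amide, along with other differences, and gives 592 nM. Both hint at a moderate gain in this assay, and a step within the scatter remains possible. The expected change is a 3.9-fold lower number from compound 2 to compound 4 (0.59 log units; beyond the scatter). For compound 4 the estimated value is 9000 nM, with an expected range of 2500 nM to 35000 nM.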

Compound 4, concentration for 50% growth inhibition: 4810 nM
For compound 4 the middle estimate is 1.9-fold (0.27 log units) above the measured one, within the range that was stated.
By their numbers in this assay, from the lowest: compound 3; then compounds 4 and 1 (each within the scatter of the next); then compound 2.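

In this assay, the change from methylcarbamoyl to isobutylcarbamoyl on an otherwise unchanged compound gives a 7.4-fold lower number from compound 2 to compound 4 (0.87 log units; beyond the scatter) as its first direct reading, a modest step beyond the scatter. This shows that the amide chain on compound 2 need not stay as small as methyl, since the larger isobutyl group in compound 4 brings stronger inhibition of growth. Nothing measured here gives a reason for this gain.

On these data alone, whether the gain depends on the branching of isobutyl or on chain length alone remains open, and a straight butyl chain on the same amide would address that. It is also unknown how far this position can be pushed, for example with a longer chain, or with a chain ending in an amine or a carboxylic acid.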